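Fluorine on the Pendant Ring: Estimating Compound 4

This account rests on a few compounds, and the source may have more. Where it says the series, first, only, none or still open, it means among the compounds named here.

Measured so far:
- Compound 1 `CC(=O)c1cc(-c2ccccc2)cc2cc(-c3ccccc3)[nH]c12` gives 65.8% in a functional assay on MCF7 cells (Homo sapiens) for cytotoxicity, read by MTT assay, with a stated time of 2 days, tested at 100 uM; a higher number here means a weaker effect of the compound at the concentration tested, a lower number a stronger effect.
- Compound 2 `COc1ccc(-c2cc(C(C)=O)c3[nH]c(-c4ccccc4)cc3c2)cc1` gives 30.8% in this assay.
- Compound 3 `CC(=O)c1cc(/C=C/c2ccccc2)cc2cc(-c3ccccc3)[nH]c12` gives 34.1% in this assay.

Compound 3 stands second highest of the three numbers. Against compound 1 the step is large, a number 31.7 percentage points lower from compound 1 to compound 3 (beyond the scatter), while against compound 2 it is a number 3.3 percentage points higher from compound 2 to compound 3 (within the scatter), so compound 2 and compound 3 cannot be told apart.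

Compound 4 `CC(=O)c1cc(/C=C/c2ccc(F)cc2)cc2cc(-c3ccccc3)[nH]c12` keeps the whole of compound 3 and changes one spot: fluoro in place of hydrogen on an aromatic carbon. The new group sits para to a large group on the outer ring of the 2-phenylethenyl arm.

Among the compounds with values here, only one measured step places a group on an outer ring: a number 35 percentage points lower from compound 1 to compound 2 (beyond the scatter), a large lowering. That group was methoxy, not fluoro, and it sat on a phenyl joined directly to the core rather than on a 2-phenylethenyl arm, so it is a loose guide at best. Within the data shown here, no step with fluoro has been measured. A small lowering, not clearly beyond the scatter, is therefore the most that is expected.

Compound 4 is estimated at 29%, within 14% to 46%, which means an expected step of a number 5.1 percentage points lower from compound 3 to compound 4 (within the scatter).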

Compound 4, a percentage reported as activity, at one concentration (the size of the read-out at that concentration, not a potency): 46.7%
Compound 4: the middle estimate sits 17.7 percentage points below what was measured; the whole stated range lies below it.
By their numbers in this assay, from the lowest: compounds 2 and 3 (each within the scatter of the next); then compound 4; then compound 1.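

On this outer ring, a single fluoro atom is enough to shift the read-out: in this assay the change gives a number 12.6 percentage points higher from compound 3 to compound 4 (beyond the scatter) and so a weaker effect at the concentration tested. The result also places the new arm in the middle ground, with a number 15.9 percentage points higher from compound 2 to compound 4 (beyond the scatter) and a number 19.1 percentage points lower from compound 1 to compound 4 (beyond the scatter) so the 2-(4-fluorophenyl)ethenyl arm keeps part of the stronger effect seen with the plain 2-phenylethenyl arm of compound 3. A group added to an outer ring therefore does not always lower the number: methoxy on the directly joined phenyl of compound 2 came with a lowering from compound 1, while fluoro on the arm of compound 4 came with a rise from compound 3, although these two changes differ in both group and arm.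

Nothing shown here explains why fluoro raises the number at this spot. On these data alone, whether the rise is particular to fluoro stays open, and methoxy, chloro or an amine at the same place on the 2-phenylethenyl arm, or fluoro on the directly joined phenyl of compound 1, would help to settle it.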